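This account rests on a few compounds, and the source may have more. Where it says the series, first, only, none or still open, it means among the compounds named here.

Measured so far, in an assay on HEK293 cells for displacement of a labelled ligand from NPC1-like intracellular cholesterol transporter 1 (Homo sapiens); on this read-out lower numbers stand for stronger inhibition and higher numbers for weaker inhibition:

Compound 1, `CC(C)(C)OC(=O)NCCCNC(=O)CN1CN(c2ccccc2)C2(CCN(C(=O)c3ccc(C4CCCCC4)cc3)CC2)C1=O`, gives 6000 nM.
Compound 2, `CC1(C)CC(OC(=O)CN2CN(c3ccccc3)C3(CCN(C(=O)c4ccc(C5CCCCC5)cc4)CC3)C2=O)CC(C)(C)N1`, gives 600 nM.
Compound 3, `O=C(CN1CN(c2ccccc2)C2(CCN(C(=O)c3ccc(C4CCCCC4)cc3)CC2)C1=O)NCCO`, gives 2000 nM.

Compound 3 sits in the middle of these three numbers. Its two neighbours lie on either side: a 3.0-fold lower number from compound 1 to compound 3 (0.48 log units; beyond the scatter), and a 3.3-fold higher number from compound 2 to compound 3 (0.52 log units; beyond the scatter). Both steps are beyond the scatter, yet both are modest.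

Compound 4, `CS(=O)(=O)NCCNC(=O)CN1CN(c2ccccc2)C2(CCN(C(=O)c3ccc(C4CCCCC4)cc3)CC2)C1=O`, differs from compound 3 in one place: methanesulfonamido in place of hydroxy on a saturated chain carbon, two bonds along the chain from an amide-type nitrogen. Among the measured compounds shown here, no measured step makes exactly this exchange. The closest guide is a 3.0-fold lower number from compound 1 to compound 3 (0.48 log units; beyond the scatter), where a group other than hydroxy stood at the same place on the chain and the number was higher; compound 4 again puts a group other than hydroxy there, though a different one. Compound 2 changes the carbonyl carbon instead, so it says little here. A modest return towards the number of compound 1 is therefore expected, a 1.8-fold higher number from compound 3 to compound 4 (0.24 log units; within the scatter), though it may fall within the scatter. For compound 4 the expected value in this assay is 3500 nM, between 1200 nM and 10000 nM.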

Compound 4, half-maximal inhibitory concentration: 2100 nM
Compound 4: the middle estimate sits 1.7-fold (0.22 log units) above what was measured; the measured number falls inside the stated range.
By their numbers in this assay, from the lowest: compound 2; then compounds 3 and 4 (each within the scatter of the next); then compound 1.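

In this assay, a group of 5 heavy atoms replaces one of 1 at the end of the chain, and the result is a 1.1-fold higher number from compound 3 to compound 4 (0.02 log units; within the scatter). So at this place on the chain, a larger group does not by itself move the number, and a group other than hydroxy does not automatically return it towards the higher value of the Boc-protected chain: the data give a 2.9-fold lower number from compound 1 to compound 4 (0.46 log units; beyond the scatter) and, on the other side, a 3.5-fold higher number from compound 2 to compound 4 (0.54 log units; beyond the scatter). Nothing shown here explains why hydroxy and methanesulfonamido read alike.

Going by these compounds, how a carboxylic acid or a primary amine would read in place of hydroxy, or a longer chain carrying methanesulfonamido, stays open. Also open, on these data alone, is whether a (2,2,6,6-tetramethylpiperidin-4-yl)amino group on the carbonyl carbon would match compound 2 600 nM.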